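Returning a Benzyl-Type Group in Place of tert-Butyl

A few compounds are considered here, and "the series" means these few. Any claim that something is new, unique, unknown or untested is made for them only; others in the source may bear on it.

For the measured compounds named here, in an in vitro functional assay on cells for agonist activity at Bombesin receptor subtype-3 (Mus musculus), read by luminescence and calcium flux (on this read-out lower numbers stand for an effect already at smaller amounts and higher numbers for an effect only at larger amounts of compound), compound 2 `CC(C)(C)Cc1cnc(CCc2ccc(-c3ccccc3C(=O)O)cc2)[nH]1` gives 6.3 nM, the lower of the two numbers measured so far. Compound 1 `O=C(O)c1ccccc1-c1ccc(CCc2ncc(CCc3ccccc3)[nH]2)cc1` gives 174 nM, and the step of a 28-fold lower number from compound 1 to compound 2 (1.44 log units; beyond the scatter) was large. Compound 3 `N#Cc1cccc(Cc2cnc(CCc3ccc(-c4ccccc4C(=O)O)cc3)[nH]2)c1` differs from compound 2 by 3-cyanophenyl in place of tert-butyl on a saturated chain carbon bound to an aromatic carbon. This largely reverses that earlier change, since a 3-cyanobenzyl group now stands where compound 1 carried benzyl and gave 174 nM. A higher number is therefore expected for compound 3, with a 13-fold higher number from compound 2 to compound 3 (1.10 log units; beyond the scatter). Compound 3 is estimated at 80 nM, in a range from 20 nM to 400 nM.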

Compound 3, half-maximal effective concentration: 20 nM
Compound 3: the middle estimate sits 4.0-fold (0.60 log units) above what was measured; the measured number falls inside the stated range.
By their numbers in this assay, from the lowest: compound 2; then compound 3; then compound 1.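

In this assay, an aromatic ring at this position costs far less than compound 1 suggested, with 3-cyanobenzyl in place of neopentyl giving a 3.2-fold higher number from compound 2 to compound 3 (0.50 log units; beyond the scatter). The change in the other direction gives an 8.7-fold lower number from compound 1 to compound 3 (0.94 log units; beyond the scatter), but it alters both the chain length and the nitrile, so their shares cannot be separated. Nothing available explains either step. From the compounds shown here alone, it remains open whether plain phenyl would match 3-cyanophenyl on this carbon, showing what the nitrile itself contributes. Going by these compounds, how an amine or a carboxylic acid on that ring would read also remains open.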